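This account rests on a few compounds, and the source may have more. Where it says the series, first, only, none or still open, it means among the compounds named here.

Compound 1 `NC1=NC2(CCOCC2)N(OCCCOc2ccccc2)C(N)=N1` was tested in an assay on isolated protein for inhibition of Dihydrofolate reductase (Homo sapiens), read by spectrophotometry, using NADPH, with stated times of 5 s and 6 min, tested at 5 uM; on this read-out lower numbers stand for a weaker effect and higher numbers for a stronger effect at the one concentration tested. In this assay compound 1 gives > 90%, which is a limit of the assay rather than a number. Compound 2 `Cc1ccc(OCCCON2C(N)=NC(N)=NC23CCOCC3)cc1` carries a methyl in place of hydrogen on an aromatic carbon. In this assay compound 2 gives > 90%, again a limit. The step that the two limits leave unreadable from compound 1 to compound 2 therefore has no readable size; what is known is only (the limit of > 90% in this assay, at which 2 of the 2 values shown sit). So compound 2 stands at a limit, with no number to fix it more closely.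

Compound 3 `CC(C)(C)c1ccc(OCCCON2C(N)=NC(N)=NC23CCOCC3)cc1` differs from compound 2 by tert-butyl in place of methyl on an aromatic carbon. Within the data shown here, the only measured step that bears on this change is a step that the two limits leave unreadable from compound 1 to compound 2, and it gives no readable size, so no step beyond the scatter is expected; the expected step is a step that the limit leaves unreadable from compound 2 to compound 3. Compound 3 is therefore expected to give 93% in this assay, within a range from 78% to 99%, most likely reported again as a limit.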

Compound 3, a percentage reported as inhibition, at one concentration (the size of the read-out at that concentration, not a potency): > 90%
Compound 3: only a limit was reported (the forecaster's own chance of this, stated with the estimate: 75%); the middle value does not contradict the limit.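

In this assay compound 3 gives > 90%, again a limit of the assay, and the steps linking compound 1, compound 2 and compound 3 cannot be read: the limit of > 90% in this assay, at which 3 of the 3 values shown sit.

The compounds shown leave open whether hydrogen, methyl and tert-butyl on the aromatic carbon differ at all in this assay.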